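Compound 3 to compound 4: a sulfonyl swap

This account rests on a few compounds, and the source may have more. Where it says the series, first, only, none or still open, it means among the compounds named here.

Measured in a functional assay on Ehrlich cells (Mus musculus) for cytotoxicity, read by trypan blue exclusion, with a stated time of 2 h; on this read-out lower numbers stand for stronger inhibition and higher numbers for weaker inhibition:
- compound 1 `CCCCNC(=S)NC1=C(C#N)C(c2ccc(Cl)cc2Cl)C2=C(CCCC2=O)N1c1ccc(S(N)(=O)=O)cc1`: > 100 ug/mL (a limit)
- compound 2 `C=CCNC(=S)NC1=C(C#N)C(c2ccc(Cl)cc2Cl)C2=C(CCCC2=O)N1c1ccc(S(N)(=O)=O)cc1`: > 100 ug/mL (a limit)
- compound 3 `N#CC1=C(NC(N)=O)N(c2ccc(S(N)(=O)=O)cc2)C2=C(C(=O)CCC2)C1c1ccc(Cl)cc1Cl`: 75 ug/mL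

Within the data shown here, compound 3 stands at 75 ug/mL, the only actual number in the set. Compound 1 and compound 2 give no number, only (the limit of > 100 ug/mL in this assay, at which 2 of the 3 values shown sit).

Compound 4 `N#CC1=C(NS(=O)(=O)c2ccc([N+](=O)[O-])cc2)N(c2ccc(S(N)(=O)=O)cc2)C2=C(C(=O)CCC2)C1c1ccc(Cl)cc1Cl` carries (4-nitrophenyl)sulfonyl in place of carbamoyl on an amine nitrogen.

Among the measured compounds shown here, two measured steps concern a change on an amine nitrogen: an at least 1.3-fold lower number from compound 1 to compound 3 (0.12 log units; that floor lies within the scatter) and an at least 1.3-fold lower number from compound 2 to compound 3 (0.12 log units; that floor lies within the scatter). Both are floors, and neither involves a sulfonyl group, which leaves the new group without a direct precedent. Resting on these two steps, no change beyond the scatter is expected in this assay, and a result reported only as a limit remains a real possibility. The expected size is a 1.1-fold higher number from compound 3 to compound 4 (0.03 log units; within the scatter). For compound 4 the estimate is 80 ug/mL, with an expected range of 35 ug/mL to 160 ug/mL.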

Compound 4, half-maximal inhibitory concentration: 20 ug/mL
The estimate for compound 4 lay 4.0-fold (0.60 log units) above the measured number; measured number below the stated range.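

In this assay, among these compounds, (4-nitrophenyl)sulfonyl in place of carbamoyl on the amine nitrogen gives a 3.8-fold lower number from compound 3 to compound 4 (0.57 log units; beyond the scatter), the first step at this position with a readable size that clears the scatter. Against the groups on the two limit compounds, the new group also clears the scatter, with an at least 5.0-fold lower number from compound 2 to compound 4 (0.69 log units; beyond the scatter) and an at least 5.0-fold lower number from compound 1 to compound 4 (0.69 log units; beyond the scatter). Both of these steps are floors and not sizes, because compound 1 and compound 2 each carry only a limit: the limit of > 100 ug/mL in this assay, at which 2 of the 4 values shown sit.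

The compounds shown do not separate the contribution of the sulfonyl link from that of the 4-nitrophenyl ring in this step. On these data alone, whether a plain phenylsulfonyl, a methanesulfonyl or a 4-aminophenylsulfonyl group on the same nitrogen would keep the lower number remains open.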